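Hydroxycarbamoyl chain change from compound 2 to compound 4

The source may hold more compounds than are shown below. What is called first, only, known or untested is meant among the compounds shown, and "the series" means these compounds.

Measured in a functional assay on NCI-H1975 cells (Homo sapiens) for antiproliferative activity, read by MTT assay, with a stated time of 72 h; on this read-out lower numbers stand for stronger inhibition and higher numbers for weaker inhibition:
- compound 1 `C=CC(=O)Nc1cc2c(Nc3ccc(F)c(Cl)c3)ncnc2cc1OCc1cn(CCC(=O)NO)nn1` gives 4450 nM
- compound 2 `C=CC(=O)Nc1cc2c(Nc3cccc(Cl)c3F)ncnc2cc1OCc1cn(CCCCC(=O)NO)nn1` gives 4180 nM
- compound 3 `C=CC(=O)Nc1cc2c(Nc3ccc(F)c(Cl)c3)ncnc2cc1OCc1cn(CCCCC(=O)NO)nn1` gives 2500 nM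

Compound 2 stands with 4180 nM inside the scatter of both other compounds, so the three values form one group and no order among them can be read. Compound 4 `C=CC(=O)Nc1cc2c(Nc3cccc(Cl)c3F)ncnc2cc1OCc1cn(CCC(=O)NO)nn1` differs from compound 2 by hydroxycarbamoyl in place of 2-(hydroxycarbamoyl)ethyl on a saturated chain carbon, two bonds along the chain from an aromatic nitrogen. In words, this is hydroxycarbamoyl in place of 2-(hydroxycarbamoyl)ethyl on a saturated chain carbon, two bonds along the chain from an aromatic nitrogen.

The same exchange, read in the opposite direction, is measured once, on the other group carried by compound 3: a 1.8-fold lower number from compound 1 to compound 3 (0.25 log units; within the scatter). The difference between compound 2 and compound 3 on that group is also small: a 1.7-fold lower number from compound 2 to compound 3 (0.22 log units; within the scatter). Neither step clears the scatter, and a single pair gives only weak support for carrying the direction over. Expected in this assay is a 1.4-fold higher number from compound 2 to compound 4 (0.16 log units; within the scatter), which means a slight drift toward a higher number and no step beyond the scatter. Compound 4 is estimated at 6000 nM, with an expected range from 3000 nM to 12000 nM.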

Compound 4, half-maximal inhibitory concentration: 6610 nM
The estimate for compound 4 lay 1.1-fold (0.04 log units) below the measured number; low and high end bracket the measured number.
By their numbers in this assay, from the lowest: compounds 3, 2, 1 and 4 (each within the scatter of the next, the first and the last beyond it).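

In this assay, the exchange of 2-(hydroxycarbamoyl)ethyl for hydroxycarbamoyl on a saturated chain carbon, two bonds along the chain from an aromatic nitrogen, can now be read with 3-chloro-2-fluorophenyl as well as with 3-chloro-4-fluorophenyl, giving a 1.6-fold higher number from compound 2 to compound 4 (0.20 log units; within the scatter), and the two readings agree: the same change on two cores in this assay, a 1.8-fold lower number (0.25 log units; within the scatter) from compound 1 to compound 3 and a 1.6-fold lower number (0.20 log units; within the scatter) from compound 4 to compound 2, 1.1-fold (0.05 log units) apart, within the scatter of two such steps

The exchange of 3-chloro-4-fluorophenyl for 3-chloro-2-fluorophenyl on a nitrogen on an aromatic ring now also has a second reading, a 1.5-fold higher number from compound 1 to compound 4 (0.17 log units; within the scatter), and this agrees with the first: the same change on two cores in this assay, a 1.7-fold lower number (0.22 log units; within the scatter) from compound 2 to compound 3 and a 1.5-fold lower number (0.17 log units; within the scatter) from compound 4 to compound 1, 1.1-fold (0.05 log units) apart, within the scatter of two such steps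

Each of the two changes thus keeps its direction on both partners, with no pair among these compounds going against it, but every single step lies within the scatter, so the agreement is a consistent drift and not an established effect of either change.

These compounds cannot tell whether chain length at this position matters at all in this read-out, since only two chain lengths are shown and their steps stay within the scatter. A longer chain ending in hydroxycarbamoyl, or a carboxylic acid or an amine in place of hydroxycarbamoyl, would be needed to show how far the position responds.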